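The compounds below may be only part of what the source reports. "The series", "measured", "known", "first", "only" and "open" are said of these compounds alone.

Compound 3 `Cc1cc(Nc2cc(-c3ccccc3)[nH]n2)n2nc(SCc3ccc(Cl)cc3)nc2n1` carries a (4-chlorobenzyl)sulfanyl group on the shared core, and in a functional assay on PC-9 cells (Homo sapiens) for inhibition, read by MTT assay, with a stated time of 72 h (on this read-out higher numbers stand for weaker inhibition and lower numbers for stronger inhibition), compound 3 gives 6710 nM. Compound 1 `Cc1ccc(CSc2nc3nc(C)cc(Nc4cc(-c5ccccc5)[nH]n4)n3n2)cc1` differs from it only in the substituent on the benzyl ring, and in this assay compound 1 gives 7310 nM; the step is a 1.1-fold lower number from compound 1 to compound 3 (0.04 log units; within the scatter). Compound 2 `Cc1cc(Nc2cc(-c3ccccc3)[nH]n2)n2ncnc2n1` lacks the whole sulfanyl group and, in this assay, compound 2 reaches only a limit, > 50000 nM. Against that limit the step to compound 3 reads an at least 7.4-fold lower number from compound 2 to compound 3 (0.87 log units; beyond the scatter), and the step from compound 1 reads an at least 6.8-fold higher number from compound 1 to compound 2 (0.83 log units; beyond the scatter). Compound 3 thus shows the lowest of the two numbers in view, with compound 1 within the scatter beside it.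

Compound 4 `Cc1cc(Nc2cc(-c3ccccc3)[nH]n2)n2nc(SCc3nc4ccccc4[nH]3)nc2n1` changes the group on the saturated chain carbon bound to a sulfur: 1H-benzimidazol-2-yl in place of 4-chlorophenyl on a saturated chain carbon bound to a sulfur. Going by the values given here, only the step from compound 1 to compound 3 touches that end of the molecule, and it stayed within the scatter, while the step from compound 2 to compound 3 shows that the group itself matters. The new group is larger and the data give no direct comparison, so compound 4 is expected to stay near compound 3, with a step of about a 1.3-fold higher number from compound 3 to compound 4 (0.13 log units; within the scatter). Compound 4 is therefore estimated at 9000 nM, between 3000 nM and 30000 nM.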

Compound 4, half-maximal inhibitory concentration: 4840 nM
Estimate against measurement, compound 4: 1.9-fold (0.27 log units) above, and the stated range covers the measured number.
By their numbers in this assay, from the lowest: compounds 4, 3 and 1 (each within the scatter of the next). At a limit, above all of these: compound 2.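

Replacing 4-chlorophenyl with 1H-benzimidazol-2-yl on a saturated chain carbon bound to a sulfur gives a 1.4-fold lower number from compound 3 to compound 4 (0.14 log units; within the scatter) in this assay, and the comparison with the methyl analogue gives a 1.5-fold lower number from compound 1 to compound 4 (0.18 log units; within the scatter). The earlier compounds shown here had tested only chloro against methyl on the benzyl ring, whereas these steps show that a larger, two-ring group carrying a hydrogen-bond donor and acceptor also stays within the scatter at this position. Adding the whole ((1H-benzimidazol-2-yl)methyl)sulfanyl group gives an at least 10-fold lower number from compound 2 to compound 4 (1.01 log units; beyond the scatter), but compound 2 stands at a limit, so this step has no fixed size: the limit of > 50000 nM in this assay, at which 1 of the 4 values shown sits.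

As far as these compounds go, how an amine or a carboxylic acid in place of the 1H-benzimidazol-2-yl group would read remains open. So does the effect of a longer chain in place of the saturated chain carbon bound to a sulfur.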